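From Diaryl Urea to Benzamide: Expecting Compound 4

This account rests on a few compounds, and the source may have more. Where it says the series, first, only, none or still open, it means among the compounds named here.

In a functional assay on NCI-H522 cells (Homo sapiens) for inhibition, read by sulforhodamine B assay, with a stated time of 48 h, tested at 1 uM (a lower number here means a stronger effect, a higher number a weaker effect of the compound at the concentration tested), compound 3 `COc1cc(Cl)cc(-c2nn(-c3cccc(NC(=O)Nc4ccc(Cl)c(Cl)c4)c3)cc2-c2ccncc2)c1` gives 60%, the highest of the three numbers measured. Among the measured compounds shown here, compound 1 `O=C(Nc1cccc(-n2cc(-c3ccncc3)c(-c3cc(O)cc(Cl)c3)n2)c1)Nc1ccc(Cl)c(Cl)c1` gives 54%, and the single measured step, a number 6 percentage points higher from compound 1 to compound 3 (within the scatter), concerns only the oxygen on the ring. For the measured compounds named here, compound 2 `COc1cc(Cl)cc(-c2nn(-c3cccc(NC(=O)Nc4cc(C(F)(F)F)cc(C(F)(F)F)c4)c3)cc2-c2ccncc2)c1` gives 18%, a far lower number than compound 3, yet no single measured step links these two compounds. Compound 4 `COc1cc(Cl)cc(-c2nn(-c3cccc(NC(=O)c4cccc(C(F)(F)F)c4)c3)cc2-c2ccncc2)c1` differs from compound 3 by 3-(trifluoromethyl)phenyl in place of (3,4-dichlorophenyl)amino on a carbonyl carbon. Going by the values given here, no measured step bears on this change, so the direction of the step is open. For compound 4 an estimated value of 45% is expected, with a range from 10% to 85%. This expectation corresponds to an expected step of a number 15 percentage points lower from compound 3 to compound 4 (beyond the scatter), not clearly beyond the scatter.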

Compound 4, a percentage reported as activity, at one concentration (the size of the read-out at that concentration, not a potency): 54%
Compound 4: the middle estimate sits 9 percentage points below what was measured; the measured number falls inside the stated range.
By their numbers in this assay, from the lowest: compound 2; then compounds 1, 4 and 3 (each within the scatter of the next).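

In this assay, among the compounds shown here, the step of a number 6 percentage points lower from compound 3 to compound 4 (within the scatter) is the first measured change at this carbonyl carbon, and it replaces the urea side with an amide. The (3,4-dichlorophenyl)amino group, with its hydrogen-bond donor, gives way to 3-(trifluoromethyl)phenyl, which has none, yet the two numbers stay within the scatter of each other. No measurement here offers an explanation for this result. Open, going by these compounds, is whether an amine or a carboxylic acid in place of the trifluoromethyl would keep the number in this range.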